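Chloro for methyl on a brominated naphthyl ketone pair

This account rests on a few compounds, and the source may have more. Where it says the series, first, only, none or still open, it means among the compounds named here.

Measured compounds:
compound 1, `Cc1cc(S(N)(=O)=O)ccc1NC(=O)COc1ccc2ccccc2c1C(=O)c1cccc(Cl)c1`: 37400 nM
compound 2, `Cc1cccc(C(=O)c2c(OCC(=O)Nc3ccc(S(N)(=O)=O)cc3C)ccc3cc(Br)ccc23)c1`: 6800 nM

Of the compounds shown here, two have been tested in an ADME assay on C8166 cells (Homo sapiens) for cytotoxicity, read by colorimetric assay and MTT assay; a lower number here means that less compound is tolerated, a higher number that more compound is tolerated. Compound 1 gives 37400 nM, and compound 2 gives 6800 nM; compound 2 therefore stands lowest of the two numbers, with compound 1 higher by a gap beyond the scatter. Among the measured compounds shown here, the two differ in two places at once, so no single step between them can be read.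

Compound 3, `Cc1cc(S(N)(=O)=O)ccc1NC(=O)COc1ccc2cc(Br)ccc2c1C(=O)c1cccc(Cl)c1`, is not yet measured. It differs from compound 2 by chloro in place of methyl on an aromatic carbon. Since compounds 1 and 3 also differ, though only in the bromo on the shared core, their two values will show only what that pair shows once compound 3 is known. A shift of modest size is expected for the step of a 1.6-fold higher number from compound 2 to compound 3 (0.21 log units; within the scatter), in the direction of a higher number, as the chloro-bearing compound 1 sits higher in this assay. Compound 3 is expected to give about 11000 nM, in a range from 4000 nM to 30000 nM.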

Compound 3, half-maximal cytotoxic concentration: 6800 nM
The estimate for compound 3 lay 1.6-fold (0.21 log units) above the measured number, and the stated range covers the measured number.
By their numbers in this assay, from the lowest: compounds 2 and 3 (each within the scatter of the next); then compound 1.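

In this assay the move from 3-methylphenyl to 3-chlorophenyl on the bromo-bearing core gives no change at the digits printed from compound 2 to compound 3 (within the scatter) and so, at this place meta to a large group, methyl and chloro cannot be told apart. The gap between compound 1 and compound 2 could not be read while they differed in two places, but bromo in place of hydrogen on an aromatic carbon now carries a 5.5-fold lower number from compound 1 to compound 3 (0.74 log units; beyond the scatter) as a single step. Nothing on hand explains either step.

On these data alone, whether an amine or a carboxylic acid at the same place on the phenyl ring would also leave the number where it stands remains open. So does whether fluoro or a methoxy group in place of the bromo would bring a step of similar size.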